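The source may hold more compounds than are shown below. What is called first, only, known or untested is meant among the compounds shown, and "the series" means these compounds.

Three compounds share one core and differ only in the group on an aromatic carbon of a six-membered aromatic ring with one nitrogen. Compound 1 `CC(C(=O)NCc1ccc(C(C)(C)C)nc1N1CCCC1)c1ccc(NS(C)(=O)=O)c(F)c1` carries a pyrrolidin-1-yl there; in an assay on cells for antagonist activity at transient receptor potential cation channel subfamily V member 1 (Homo sapiens), read by FLIPR and calcium flux, with a stated time of 6 min (on this read-out lower numbers stand for stronger inhibition and higher numbers for weaker inhibition), compound 1 gives 1.2 nM. Compound 2 `CC(C)CCOc1nc(C(C)(C)C)ccc1CNC(=O)C(C)c1ccc(NS(C)(=O)=O)c(F)c1` carries an isopentyloxy instead, and in this assay compound 2 gives 0.8 nM. Compound 3 `CC(C(=O)NCc1ccc(C(C)(C)C)nc1OCc1ccc(F)cc1)c1ccc(NS(C)(=O)=O)c(F)c1` carries a (4-fluorobenzyl)oxy, and in this assay compound 3 gives 0.8 nM, level with compound 2 and together with it the lowest of the three numbers, though all three lie within the usual scatter of one another: a 1.5-fold lower number from compound 1 to compound 2 (0.18 log units; within the scatter), a 1.5-fold lower number from compound 1 to compound 3 (0.18 log units; within the scatter), and no change at the digits printed from compound 2 to compound 3 (within the scatter).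

Compound 4 `CC(C(=O)NCc1ccc(C(C)(C)C)nc1SCCCN1CCCC1)c1ccc(NS(C)(=O)=O)c(F)c1` is not yet measured. It differs from compound 3 by (3-(pyrrolidin-1-yl)propyl)sulfanyl in place of (4-fluorobenzyl)oxy on an aromatic carbon. The three measured steps all change the group at this same place, and each stayed within the scatter, so a fourth change there is expected to do the same, with a 1.3-fold higher number from compound 3 to compound 4 (0.10 log units; within the scatter) and no direction beyond the noise. Compound 4 is therefore estimated to give 1 nM in this assay, with a range from 0.3 nM to 4 nM.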

Compound 4, inhibition constant: 17.1 nM
The estimate for compound 4 lay 17-fold (1.23 log units) below the measured number, and the stated range ends below it.
By their numbers in this assay, from the lowest: compounds 2, 3 and 1 (each within the scatter of the next); then compound 4.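

This position does not accept every group equally: in this assay, the (3-(pyrrolidin-1-yl)propyl)sulfanyl group gives a 21-fold higher number from compound 3 to compound 4 (1.33 log units; beyond the scatter), a 21-fold higher number from compound 2 to compound 4 (1.33 log units; beyond the scatter) and a 14-fold higher number from compound 1 to compound 4 (1.15 log units; beyond the scatter), all toward weaker inhibition, whereas the three earlier groups could not be told apart. The number of heavy atoms alone does not separate the groups, as the (4-fluorobenzyl)oxy and (3-(pyrrolidin-1-yl)propyl)sulfanyl groups hold the same count, yet the step is large; a pyrrolidine ring alone does not track with the weaker number either, as compound 1 carries one directly on the aromatic carbon and stays within the scatter of compound 2 and compound 3. Nothing available here explains why this group behaves differently.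

The step swaps a sulfur link for an oxygen link and also brings in a chain ending in a pyrrolidine ring, so the compounds shown cannot say which of these two changes matters, and an isopentylsulfanyl group or a (3-(pyrrolidin-1-yl)propyl)oxy group would separate them. From the compounds shown here alone, it also stays open whether a shorter chain, or a chain ending in a morpholine ring or a carboxylic acid, would give the same result.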